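This account rests on a few compounds, and the source may have more. Where it says the series, first, only, none or still open, it means among the compounds named here.

In a functional assay on KB cells (Homo sapiens) for antiproliferative activity, read by MTT assay, with a stated time of 72 h (a higher number here means a weaker inhibitor, a lower number a stronger inhibitor), compound 1 `CCOC(=O)c1cc(-c2cc(OC)c(OC)c(OC)c2)c(-c2ccc(OC)c([N+](=O)[O-])c2)s1` gives 15800 nM and compound 2 `COc1ccc(-c2sccc2-c2cc(OC)c(OC)c(OC)c2)cc1` gives 8880 nM with the two numbers lying within the usual scatter of each other. Among the measured compounds shown here, compound 2 therefore stands level with the only other measured compound. Compound 3 `COc1ccc(-c2sccc2-c2cc(OC)c(OC)c(OC)c2)cc1[N+](=O)[O-]` differs from compound 2 by a single change, a nitro in place of hydrogen on an aromatic carbon with the rest left as it was. Compound 1 also carries a nitro group and gives 15800 nM so in this assay no step beyond the scatter is expected in either direction. The estimated change a 1.1-fold higher number from compound 2 to compound 3 (0.03 log units; within the scatter) is expected to stay small. Compound 3 is estimated at 9500 nM with an expected range from 3000 nM to 30000 nM around that middle.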

Compound 3, half-maximal inhibitory concentration: 10600 nM
Beside the measured number, compound 3's estimate is 1.1-fold (0.05 log units) below it; measured number inside the range.
By their numbers in this assay, from the lowest: compounds 2, 3 and 1 (each within the scatter of the next).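

In this assay a nitro on the aromatic carbon ortho to a methoxy group gives a 1.2-fold higher number from compound 2 to compound 3 (0.08 log units; within the scatter) and so moves the number no further than the scatter. Hydrogen in place of ethoxycarbonyl on an aromatic carbon gives a 1.5-fold lower number from compound 1 to compound 3 (0.17 log units; within the scatter) and is also within the scatter, so with the nitro present, the ester makes no readable difference. No measurement shown gives a reason for either result.
Still open, going by these compounds, is whether an amine in place of the nitro would read differently, and likewise a carboxylic acid in place of the ethoxycarbonyl.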